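The source may hold more compounds than are shown below. What is called first, only, known or untested is meant among the compounds shown, and "the series" means these compounds.

Of the compounds shown here, two built on the shared core have been tested so far, compound 1 `CCOc1ccc(NC2=CC(=O)c3c(nc4n3[C@H]3OC[C@@H](O)[C@H]3OC4)C2=O)cc1` and compound 2 `CCCN(CCC)C1=CC(=O)c2c(nc3n2[C@H]2OC[C@@H](O)[C@H]2OC3)C1=O`. In a functional assay on MCF7 cells (Homo sapiens) for inhibition, read by sulforhodamine B assay (a lower number here means a stronger inhibitor, a higher number a weaker inhibitor), compound 2 gives > 16000 nM, which is a limit of the assay and not a number. Compound 3 `O=C1C(Nc2cccc(Cl)c2)=CC(=O)c2c1nc1n2[C@H]2OC[C@@H](O)[C@H]2OC1` has not yet been measured. It carries (3-chlorophenyl)amino in place of dipropylamino on a double-bonded ring carbon. Among the compounds with values here, no measured pair of compounds isolates this kind of change, so any expectation must rest on a single neighbour. That neighbour is compound 1, which also has an aromatic ring on its amino nitrogen and whose limit in this assay is > 4000 nM. This is a limit too, so compound 1 and compound 2 cannot be ranked against each other. A modest gain in strength is the most that can be expected, and a second result reported only as a limit would be no surprise. The expected change is an at least 2.6-fold lower number from compound 2 to compound 3 (0.42 log units; beyond the scatter). For compound 3 the estimated value is 6000 nM, with an expected range from 1500 nM to 25000 nM.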

Compound 3, half-maximal inhibitory concentration: 2970 nM
Compound 3: middle estimate off by 2.0-fold (0.31 log units), on the high side, and the stated range covers the measured number.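

In this assay, within the data shown here, compound 3 gives 2970 nM, the first real number at this position rather than a limit of the assay, and (3-chlorophenyl)amino in place of dipropylamino on the double-bonded ring carbon gives an at least 5.3-fold lower number from compound 2 to compound 3 (0.73 log units; beyond the scatter), which shows that the group carried here can change the result. The step for 3-chlorophenyl in place of 4-ethoxyphenyl on the amine nitrogen is an at least 1.3-fold lower number from compound 1 to compound 3 (0.12 log units; that floor lies within the scatter), so these two compounds with an aromatic ring on that nitrogen cannot be put in order. Compound 2 stands at a limit of the assay, so the first step gives only a floor for the size of the change: the limit of > 16000 nM in this assay, at which 1 of the 3 values shown sits.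

That step swaps two chains for an aromatic ring and also adds a hydrogen-bond donor, and the compounds shown cannot separate these two changes; a propylamino group, which has a hydrogen on the nitrogen but no aromatic ring, would begin to do so. As far as these compounds go, the part played by the chlorine also stays open, and plain phenylamino would address it.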